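A few compounds are considered here, and "the series" means these few. Any claim that something is new, unique, unknown or untested is made for them only; others in the source may bear on it.

This account follows the cytotoxicity of a small set of aminothiazole amides sharing one core. Compound 1 `COc1cccc(-c2csc(NC(=O)c3ccco3)n2)c1` and compound 2 `COc1cccc(-c2csc(NC(=O)c3ccc([N+](=O)[O-])cc3)n2)c1` each carry a 3-methoxyphenyl arm on that core. In an ADME assay on Vero cells (Chlorocebus sabaeus) for cytotoxicity, read by MTT assay, with a stated time of 72 h (a higher number here means a weaker inhibitor, a lower number a stronger inhibitor), compound 1 reaches only the limit of the assay, > 90000 nM, which is not a number. Compound 2 likewise gives only a limit in this assay, > 90000 nM. Going by the values given here, compound 3 `O=C(Nc1nc(-c2ccccc2)cs1)c1ccc([N+](=O)[O-])o1` is therefore the one member with an actual measured value: in this assay compound 3 gives 41700 nM. Among the compounds with values here, it stands alone as the single number among the three entries, as summarised by the limit of > 90000 nM in this assay, at which 2 of the 3 values shown sit.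

Compound 4 `COc1cccc(-c2csc(NC(=O)c3ccc([N+](=O)[O-])o3)n2)c1` differs from compound 3 in a single place: methoxy in place of hydrogen on an aromatic carbon, so that the plain phenyl of compound 3 becomes the 3-methoxyphenyl seen in compound 1 and compound 2. Within the data shown here, no measured pair isolates this change. Compound 4 is expected to be somewhat weaker than compound 3, the step from compound 3 to compound 4 being estimated at a 1.6-fold higher number from compound 3 to compound 4 (0.19 log units; within the scatter), because compound 1 at > 90000 nM and compound 2 at > 90000 nM both carry the methoxy and both sit at the limit. Compound 4 is accordingly estimated at 65000 nM, within a range of 25000 nM to 160000 nM.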

Compound 4, half-maximal inhibitory concentration: 58700 nM
The estimate for compound 4 lay 1.1-fold (0.04 log units) above the measured number; low and high end bracket the measured number.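

In this assay, the change from phenyl to 3-methoxyphenyl now has a measured pair, and it gives a 1.4-fold higher number from compound 3 to compound 4 (0.15 log units; within the scatter), so the methoxy leaves compound 3 and compound 4 indistinguishable in this assay. Nitro in place of hydrogen on an aromatic carbon, the other single change now open to reading, gives an at least 1.5-fold lower number from compound 1 to compound 4 (0.18 log units; that floor lies within the scatter). That step can be read only as a floor, not as a size, because compound 1 stands at a limit and not at a number: the limit of > 90000 nM in this assay, at which 2 of the 4 values shown sit.

The compounds shown leave open whether a different group in place of the methoxy, such as a hydroxyl, an amine or a longer chain like butoxy, would give a step beyond the scatter. They also leave open how large the step from compound 1 to compound 4 really is.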